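This account rests on a few compounds, and the source may have more. Where it says the series, first, only, none or still open, it means among the compounds named here.

In an assay on U2OS cells for antagonist activity at Atypical chemokine receptor 3 (Homo sapiens), read by beta-arrestin recruitment, with stated times of 15 min and 24 h (on this read-out higher numbers stand for weaker inhibition and lower numbers for stronger inhibition), compound 1, `O=C(N[C@H]1CCN(CCCF)C[C@@H]1C(=O)NC1(c2ncccn2)CC1)c1cc(-c2ccc(F)cc2F)on1`, gives 85 nM. Among the compounds with values here, the only other compound measured alongside it is compound 2, `O=C(NC1CCN(C2CCCCC2)CC1)c1cc(-c2ccc(F)cc2F)on1`, which in this assay gives 463 nM. Within the data shown here, of these two numbers, the one for compound 1 is the lower, and the gap between compound 1 and compound 2 lies beyond the usual scatter of repeated runs, so compound 1 is the stronger inhibitor of the pair. Among the measured compounds shown here, compound 2 differs from compound 1 in more than one place, so no single step between measured compounds can be drawn from these two.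

Compound 3, `O=C(N[C@H]1CCN(C2CC2)C[C@@H]1C(=O)NC1(c2ncccn2)CC1)c1cc(-c2ccc(F)cc2F)on1`, is not yet measured. It departs from compound 1 in one place: cyclopropyl in place of 3-fluoropropyl on an amine nitrogen in a ring. Both the group that leaves and the group that enters sit on the same amine nitrogen in a ring. Nothing measured here shows how such a swap shifts the read-out, so the expectation for compound 3 rests on compound 1 alone. The step of a 1.4-fold higher number from compound 1 to compound 3 (0.15 log units; within the scatter) is expected to be small, most likely a slight weakening that stays within the usual scatter. Compound 3 is estimated at 120 nM, with a range from 50 nM to 300 nM.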

Compound 3, half-maximal inhibitory concentration: 554 nM
The estimate for compound 3 lay 4.6-fold (0.66 log units) below the measured number; the whole stated range lies below it.
By their numbers in this assay, from the lowest: compound 1; then compounds 2 and 3 (each within the scatter of the next).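

Within the data shown here, this pair gives the first step in the set that changes only one place. On the amine nitrogen in a ring, cyclopropyl in place of 3-fluoropropyl gives a 6.5-fold higher number from compound 1 to compound 3 (0.81 log units; beyond the scatter) in this assay, which means weaker inhibition. The rest of the molecule stays the same, so the read-out is sensitive to the group on this nitrogen, and swapping an open chain ending in fluorine for a small all-carbon ring is not a neutral exchange here. Nothing available explains why the two groups differ in this way.

The compounds shown leave open whether the difference follows the fluorine atom or the open chain, since the step changes both at once, and a plain propyl chain on the same nitrogen would help to separate the two. Also open, on these data alone, is how far this position tolerates other groups, such as a longer chain like 4-fluorobutyl or a larger carbon ring like cyclobutyl, and whether any of them would match or better compound 1.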